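This account rests on a few compounds, and the source may have more. Where it says the series, first, only, none or still open, it means among the compounds named here.

Measured so far in an assay on CHO-K1 cells for displacement of a labelled ligand from prostaglandin E2 receptor EP1 subtype (Homo sapiens); on this read-out lower numbers stand for stronger inhibition and higher numbers for weaker inhibition:
compound 1 `Cc1cc(C(=O)O)nn1Cc1cc(Br)ccc1OCc1ccccc1` gives 6.46 nM
compound 2 `Cc1cc(C(=O)O)nn1Cc1cc(Br)ccc1OCc1c(F)cccc1F` gives 14.8 nM

Compound 1 has the lowest of the two numbers recorded in this assay; its nearest neighbour is compound 2, and the step of a 2.3-fold higher number from compound 1 to compound 2 (0.36 log units; beyond the scatter) lies beyond the scatter. Compound 3 `Cc1cc(C(=O)O)nn1Cc1cc(Br)ccc1OCc1ccc(C(C)(C)C)cc1` has not yet been measured. It differs from compound 1 by tert-butyl in place of hydrogen on an aromatic carbon, the added group sitting on an aromatic carbon of a six-membered aromatic ring of carbon only, para to a large group. Going by the values given here, only one measured step concerns this ring, a 2.3-fold higher number from compound 1 to compound 2 (0.36 log units; beyond the scatter), and it alters a different part of the ring with a different kind of group, so it bears on the new change only loosely. Among the compounds with values here, no measured pair shows what an added tert-butyl does here. Within the data shown here, the expectation is therefore a modest step at most in this assay, in either direction, with a slight lean toward a higher number, since the one change seen on this ring, compound 1 to compound 2, gave a 2.3-fold higher number from compound 1 to compound 2 (0.36 log units; beyond the scatter). The estimated step is a 1.5-fold higher number from compound 1 to compound 3 (0.19 log units; within the scatter). Compound 3 is thus expected to give about 10 nM, within a range of 3 nM to 35 nM.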

Compound 3, half-maximal inhibitory concentration: 1230 nM
Compound 3: the middle estimate sits 120-fold (2.09 log units) below what was measured; measured number above the stated range.
By their numbers in this assay, from the lowest: compound 1; then compound 2; then compound 3.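

In this assay, tert-butyl in place of hydrogen on an aromatic carbon, para to a large group, gives a 190-fold higher number from compound 1 to compound 3 (2.28 log units; beyond the scatter), a large step. The only earlier change on this ring, a 2.3-fold higher number from compound 1 to compound 2 (0.36 log units; beyond the scatter), was modest, so the ring had not yet shown that a single added group could raise the number this far. No evidence at hand says what lies behind this step.

The compounds shown leave open whether a methyl group or a chlorine atom on the same aromatic carbon would stay close to compound 1, which gives 6.46 nM, or would also bring a large step. They also leave open whether tert-butyl on another carbon of this ring would raise the number as far.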